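The compounds below may be only part of what the source reports. "The series", "measured", "known", "first", "only" and "open" are said of these compounds alone.

Compounds measured so far in an assay on HEK293 cells for activation of Kir3.1/Kir3.2 (Homo sapiens), read by thallium flux; on this read-out higher numbers stand for larger maximal responses and lower numbers for smaller maximal responses:

Compound 1 `Cc1cc(NC(=O)Cn2nnc(-c3cc(Cl)cc(Cl)c3)n2)n(C2CCCCC2)n1` gives 82%.
Compound 2 `Cc1cc(NC(=O)Cn2nnc(-c3ccccc3F)n2)n(C2CCCCC2)n1` gives 88%.
Compound 3 `Cc1ccc(-c2nnn(CC(=O)Nc3cc(C)nn3C3CCCCC3)n2)cc1` gives 86%.

Compound 3 stands second highest of the three numbers in this assay; the nearest step to it is a number 2 percentage points lower from compound 2 to compound 3 (within the scatter) and the furthest is a number 4 percentage points higher from compound 1 to compound 3 (within the scatter), so all three sit within the scatter of one another. Compound 4 `Cc1cc(NC(=O)Cn2nnc(C3CC3)n2)n(C2CCCCC2)n1` differs from compound 3 by cyclopropyl in place of 4-methylphenyl on an aromatic carbon. The measured steps, a number 6 percentage points higher from compound 1 to compound 2 (within the scatter) and a number 4 percentage points higher from compound 1 to compound 3 (within the scatter), each exchange one aryl ring for another at this place and none of them moves the read-out beyond the scatter. Going by the values given here, no measured step replaces the aryl ring with a non-aromatic ring, so none bears directly on the change to compound 4; the steps so far only show that the identity of the group at this place has made little difference. The expected step is therefore a number 8 percentage points lower from compound 3 to compound 4 (within the scatter), small and with wide uncertainty in either direction. Compound 4 is estimated at 78%, within a range of 55% to 95%.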

Compound 4, largest response reached (Emax), in percent of the reference or control that the assay uses: > 68%
Compound 4: only a limit was reported (the forecaster's own chance of this, stated with the estimate: 0%); the middle value is on the limit's open side.
By their numbers in this assay, from the lowest: compounds 1, 3 and 2 (each within the scatter of the next).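

In this assay compound 4 gives > 68%, which is a limit and not a number. The steps to compound 4 from compounds 1, 2 and 3 therefore cannot be read. The compounds shown leave open whether cyclopropyl in place of these aryl groups changes the maximal response in this assay.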